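The compounds below may be only part of what the source reports. "The series", "measured", "known", "first", "only" and "open" are said of these compounds alone.

Of the compounds shown here, three have been measured so far. In a functional assay on T98G cells (Homo sapiens) for inhibition, read by colorimetric assay and MTT assay, with a stated time of 72 h (a lower number here means a stronger inhibitor, a higher number a weaker inhibitor), compound 1 (`C=CCCCCOc1ccccc1-c1cnc(OCCC=C)n1C`) gives 29000 nM, compound 2 (`C=CCCCCOc1cc2ccccc2cc1-c1cnc(OCCCCC=C)n1C`) gives 40000 nM and compound 3 (`C=CCCCCCOc1ncc(-c2ccccc2OCCCCC=C)n1C`) gives 63000 nM. The numbers for compound 2 and compound 3 lie within the scatter of each other, so they cannot be ranked. Compound 1 stands apart, and the measured step is a 2.2-fold higher number from compound 1 to compound 3 (0.34 log units; beyond the scatter).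

The next compound is compound 4 (`C=CCCCCOc1ccccc1-c1cnc(OCCOCC=C)n1C`). It places allyloxy where compound 3 carries pent-4-en-1-yl, on a saturated chain carbon, two bonds along the chain from an oxygen on an aromatic ring: allyloxy in place of pent-4-en-1-yl on a saturated chain carbon, two bonds along the chain from an oxygen on an aromatic ring. Cut one bond further out, the same change reads (hept-6-en-1-yl)oxy to 2-(allyloxy)ethoxy. Both groups end in a double bond.

Among the measured compounds shown here, only one measured step touches this place, the modest change from vinyl to pent-4-en-1-yl, and no measured compound has allyloxy there. The evidence is therefore thin, and only a small shift in this assay is expected, toward a lower number and within the scatter. The expected step is a 1.4-fold lower number from compound 3 to compound 4 (0.15 log units; within the scatter). For compound 4 the estimated value is 45000 nM, with an expected range from 20000 nM to 95000 nM.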

Compound 4, half-maximal inhibitory concentration: 65000 nM
Estimate against measurement, compound 4: 1.4-fold (0.16 log units) below, and the stated range covers the measured number.
By their numbers in this assay, from the lowest: compounds 1, 2, 3 and 4 (each within the scatter of the next, the first and the last beyond it).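

In this assay the place now carries a chain with an oxygen in it, and allyloxy in place of pent-4-en-1-yl gives a 1.0-fold higher number from compound 3 to compound 4 (0.01 log units; within the scatter) and so leaves compound 3 and compound 4 impossible to tell apart, even though allyloxy brings one hydrogen-bond acceptor that pent-4-en-1-yl lacks. Set against the vinyl group, allyloxy gives a 2.2-fold higher number from compound 1 to compound 4 (0.35 log units; beyond the scatter) and pent-4-en-1-yl gives a 2.2-fold higher number from compound 1 to compound 3 (0.34 log units; beyond the scatter) in the same assay, so two different replacements of vinyl at this place now point the same way, each by a modest step just beyond the scatter. No measurement on hand accounts for these numbers.

Among the compounds shown here, every group at this place so far is a chain ending in a double bond, so it remains open whether the double bond matters at all, which a plain saturated hexyl chain could test. As far as these compounds go, it is equally open whether a chain ending in an amine or a carboxylic acid, or a group shorter than vinyl such as methyl, would move the number in either direction.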